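The source may hold more compounds than are shown below. What is called first, only, known or untested is meant among the compounds shown, and "the series" means these compounds.

Within the data shown here, compound 1 `CNC(=O)c1cc(C(=O)NC2CC2)cn(Cc2cccc(F)c2)c1=O` is one of two compounds measured in a physicochemical assay for lipophilicity, at pH 7.4 (a higher number here means a more lipophilic compound, a lower number a more polar compound), so far. In this assay compound 1 gives 3.2. Among the measured compounds shown here, the only other measured compound is compound 2 `CNC(=O)c1cc(C(=O)NC2CC2)c(C)n(Cc2ccccc2)c1=O`, which in this assay gives 2.9; the gap between compound 1 and compound 2 lies within the usual scatter of repeated measurements, so the two numbers cannot be told apart. For the measured compounds named here, compound 2 also differs from compound 1 in more than one place, so it gives no clean step to read from.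

The unmeasured compound is compound 3 `CNC(=O)c1cc(C(=O)NC2CC2)cn(CC2CCOCC2)c1=O`. Its structure departs from that of compound 1 in a single place: oxan-4-yl in place of 3-fluorophenyl on a saturated chain carbon bound to an aromatic nitrogen. The group that leaves is an aromatic ring carrying a fluorine, and the group that enters is a saturated ring with one hetero atom and one hydrogen-bond acceptor.

Going by the values given here, no measured pair shows this change, so the expectation rests on the structural change alone. The estimated step from compound 1 to compound 3 in this assay is a number 1.40 log units lower from compound 1 to compound 3 (beyond the scatter), a decrease expected to reach beyond the scatter. Compound 3 is therefore estimated at 1.8 in this assay, with a range from 1.2 to 2.4.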

Compound 3, distribution coefficient: 1.5
For compound 3 the middle estimate is 0.30 log units above the measured one; the range from low to high includes it.
By their numbers in this assay, from the lowest: compound 3; then compounds 2 and 1 (each within the scatter of the next).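

Among these compounds, until now, no two compounds measured in this assay differed in only one place, so this is the first change on the shared core that can be read cleanly. Replacing 3-fluorophenyl with oxan-4-yl on a saturated chain carbon bound to an aromatic nitrogen gives a number 1.70 log units lower from compound 1 to compound 3 (beyond the scatter) and the step is large, which shows that the number in this assay can depend strongly on the group held at this place. Nothing in the data shown accounts for the size of this step, so it stands as an observation without an explanation.

This single swap alters several features at once: the aromatic ring gives way to a non-aromatic one, the fluorine leaves, and a ring oxygen with its hydrogen-bond acceptor enters, so the compounds shown leave open which of these features carries the step. A cyclohexyl group in the same place would keep the saturated ring without the oxygen, while a piperidin-4-yl group would put a ring amine there instead, and how either would read in this assay remains an open question.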